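The source may hold more compounds than are shown below. What is called first, only, known or untested is meant among the compounds shown, and "the series" means these compounds.

Compound 1 `CCN1C(=O)N(CC)C2C1NC(=S)N2/N=C/C=C/c1ccccc1` is the parent of this small set. In a functional assay on MCF7 cells (Homo sapiens) for inhibition, read by MTT assay, with a stated time of 72 h (a higher number here means a weaker inhibitor, a lower number a stronger inhibitor), compound 1 gives 36100 nM. Compound 2 `CCN1C(=O)N(CC)C2C1NC(=S)N2/N=C/C=C/c1ccccc1[N+](=O)[O-]` carries one change from it, (nitro in place of hydrogen on an aromatic carbon), and in this assay compound 2 gives 43900 nM; the step of a 1.2-fold higher number from compound 1 to compound 2 (0.08 log units; within the scatter) shows that this change left potency essentially unchanged.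

Compound 3 `CCN1C(=O)N(CC)C2C1N=C(SC)N2/N=C/C=C/c1ccccc1` has a different core; the difference between the two cores is not broken down here. In this assay compound 3 gives 46600 nM, a value that sits within the scatter of both compound 1 and compound 2.

Compound 4 `CCN1C(=O)N(CC)C2C1N=C(SC)N2/N=C/C=C/c1ccccc1[N+](=O)[O-]` is not yet measured. Within the data shown here, it differs from compound 3 by nitro in place of hydrogen on an aromatic carbon, the same change, at the same place, as the one that turns compound 1 into compound 2. Because a 1.2-fold higher number from compound 1 to compound 2 (0.08 log units; within the scatter) was within the scatter, the step of a 1.2-fold higher number from compound 3 to compound 4 (0.08 log units; within the scatter) is expected to be equally small. On that basis compound 4 is estimated at 56000 nM, most likely between 28000 nM and 112000 nM.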

Compound 4, half-maximal inhibitory concentration: 66700 nM
Compound 4: middle estimate off by 1.2-fold (0.08 log units), on the low side, within the range that was stated.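

In this assay, nitro in place of hydrogen on an aromatic carbon gives the step of a 1.4-fold higher number from compound 3 to compound 4 (0.16 log units; within the scatter), and the same change on the core of compound 1 looks much the same: the same change on two cores in this assay, a 1.2-fold higher number (0.08 log units; within the scatter) from compound 1 to compound 2 and a 1.4-fold higher number (0.16 log units; within the scatter) from compound 3 to compound 4, 1.2-fold (0.07 log units) apart, within the scatter of two such steps. So on both cores the change stays within the usual scatter, and the small step seen on the core of compound 1 also holds on the core of compound 3. Among these compounds, this shows only that the step stays small for this one group, at this one place, on these two cores; it does not show that a change with a large step would carry over in the same way.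

The compounds shown leave open whether another group on the aromatic ring, such as an amine or a carboxylic acid, would give a step beyond the scatter. They also leave open what a longer chain on the shared core would do on either core.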